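The compounds below may be only part of what the source reports. "The series", "measured", "known", "first", "only" and "open" are said of these compounds alone.

Two compounds share one core and differ only in the group attached to the amide carbonyl carbon. Compound 1 `Cc1ccccc1C(=O)N[C@@H](C(=O)N1CCC(c2ccc(Cl)cc2)CC1)C(C)C` gives 32 nM in an assay on THP-1 cells for displacement of a labelled ligand from C-C chemokine receptor type 1 (Homo sapiens) (a lower number here means a stronger inhibitor, a higher number a weaker inhibitor), while compound 2 `Cc1ccc(CCC(=O)N[C@@H](C(=O)N2CCC(c3ccc(Cl)cc3)CC2)C(C)C)cc1` gives 105 nM in this assay. Compound 2 thus holds the highest of the two numbers, and its nearest neighbour is compound 1, separated by the step of a 3.3-fold higher number from compound 1 to compound 2 (0.52 log units; beyond the scatter), which lies beyond the scatter. Compound 3 `CC(C)[C@@H](NC(=O)c1cc2ccccc2s1)C(=O)N1CCC(c2ccc(Cl)cc2)CC1` carries 1-benzothiophen-2-yl in place of 2-(4-methylphenyl)ethyl on a carbonyl carbon, so the 1-benzothiophen-2-yl group now sits on the carbonyl carbon where compound 2 had the 2-(4-methylphenyl)ethyl group. For the measured compounds named here, the only measured step that bears on this change is a 3.3-fold higher number from compound 1 to compound 2 (0.52 log units; beyond the scatter), in which exchanging an aromatic ring on the carbonyl carbon for an arylethyl group raised the number. Returning an aromatic ring to that carbonyl carbon is expected to reverse that step in this assay, so the step from compound 2 to compound 3 is expected to be a 3.0-fold lower number from compound 2 to compound 3 (0.48 log units; beyond the scatter). Compound 3 is therefore estimated to give 35 nM in this assay, with a range from 12 nM to 110 nM.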

Compound 3, half-maximal inhibitory concentration: 58 nM
Beside the measured number, compound 3's estimate is 1.7-fold (0.22 log units) below it, and the stated range covers the measured number.
By their numbers in this assay, from the lowest: compounds 1, 3 and 2 (each within the scatter of the next, the first and the last beyond it).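

Set against each other in this assay, the two new steps, a 1.8-fold lower number from compound 2 to compound 3 (0.26 log units; within the scatter) and a 1.8-fold higher number from compound 1 to compound 3 (0.26 log units; within the scatter), both stay within the scatter. The earlier pair had shown a separation beyond the scatter between 2-methylphenyl and 2-(4-methylphenyl)ethyl on this carbonyl carbon, and 1-benzothiophen-2-yl cannot be told apart from either of them, so the position also accepts a group with a five-membered aromatic ring holding one hetero atom alongside a six-membered aromatic ring of carbon only, without a change that can be read in this measurement. Nothing at hand explains why these three groups fall as they do.

The compounds shown leave open whether the sulfur atom of 1-benzothiophen-2-yl matters at all, a question that a naphthalen-2-yl group, or a thiophen-2-yl group without the six-membered ring, would bear on. They also leave open how this carbonyl carbon responds to groups of another kind, such as a benzyl group with a shorter chain, or an aryl ring carrying an amine or a carboxylic acid.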